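This account rests on a few compounds, and the source may have more. Where it says the series, first, only, none or still open, it means among the compounds named here.

Working notes on the series. In a functional assay on QGY-7703 cells (Homo sapiens) for cytotoxicity, read by MTT assay, with a stated time of 24 h (a higher number here means a weaker inhibitor, a lower number a stronger inhibitor), compound 1 `CN1C/C(=C\c2ccncc2)C(=O)/C(=C/c2ccccc2F)C1` gives 4900 nM and compound 2 `CN1C/C(=C\c2ccncc2)C(=O)/C(=C/c2ccc(F)cc2Br)C1` gives 6900 nM with the two numbers within the usual scatter of each other, so compound 2 stands level with compound 1. Compound 3 `CN1C/C(=C\c2ccncc2)C(=O)/C(=C/c2ccc(C#N)cc2)C1` is still unmeasured. Relative to compound 2 it carries 4-cyanophenyl in place of 2-bromo-4-fluorophenyl on a double-bonded chain carbon bound to a double-bonded ring carbon on a double-bonded chain carbon bound to a double-bonded ring carbon. Among the compounds with values here, one measured step bears on this change, namely a 1.4-fold higher number from compound 1 to compound 2 (0.15 log units; within the scatter) at that same place, and it stays within the scatter. Within the data shown here, it is the only evidence available, and neither measured compound carries a nitrile, so it covers the entering group only loosely. No step beyond the scatter is expected in this assay and no direction is favoured, though a wide range is kept for the untested 4-cyanophenyl. The expected size is a 1.2-fold lower number from compound 2 to compound 3 (0.08 log units; within the scatter) on this estimate. For compound 3 the estimated value is 5800 nM with an expected range of 2200 nM to 15000 nM on present evidence.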

Compound 3, half-maximal inhibitory concentration: 7400 nM
Estimate against measurement, compound 3: 1.3-fold (0.11 log units) below; low and high end bracket the measured number.
By their numbers in this assay, from the lowest: compounds 1, 2 and 3 (each within the scatter of the next).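

Working notes, continued. In this assay, within the data shown here, the comparison at this place, on a double-bonded chain carbon bound to a double-bonded ring carbon, now reaches a group with a nitrile and no fluorine or bromine, and the result stays level with the earlier compounds both against 2-bromo-4-fluorophenyl (a 1.1-fold higher number from compound 2 to compound 3 (0.03 log units; within the scatter)) and against 2-fluorophenyl (a 1.5-fold higher number from compound 1 to compound 3 (0.18 log units; within the scatter)). Across the three compounds shown, this place therefore accepts all three substituted phenyl groups with no step beyond the scatter, even though 4-cyanophenyl brings a triple bond and a hydrogen-bond acceptor that 2-bromo-4-fluorophenyl lacks. Nothing available explains this flat response.

The compounds shown leave open whether any group at this place can move the number beyond the scatter, since all three carry a substituted phenyl and none an amine, a carboxylic acid or a longer chain in its place. They also leave open how much the rest of the shared core contributes, since it stays the same in all three compounds and every comparison here rests on this single cell assay.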